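Chain shortening on the aromatic nitrogen: cytotoxicity notes

The source may hold more compounds than are shown below. What is called first, only, known or untested is meant among the compounds shown, and "the series" means these compounds.

Three compounds of the series have an entry in an ADME assay on Huh-7 cells (Homo sapiens) for cytotoxicity, with a stated time of 72 h (on this read-out higher numbers stand for lower toxicity in this test and lower numbers for higher toxicity in this test), though only one carries a read-out. Compound 1 `CC(C)CCn1nc(-c2cccs2)c(O)c(C2=NS(=O)(=O)c3cc(N(C(C)C)S(C)(=O)=O)ccc3N2)c1=O` gives "not determined" (no result reported) in this assay. Compound 2 `CC(C)CCn1nc(-c2cccs2)c(O)c(C2=NS(=O)(=O)c3cc(S(=O)(=O)N(C)C)ccc3N2)c1=O` likewise gives "not determined" (no result reported) in this assay. Compound 3 `CC(C)(C)CCn1nc(-c2cccs2)c(O)c(C2=NS(=O)(=O)c3cc(NS(C)(=O)=O)ccc3N2)c1=O` is the only one with a result, and that result is a limit of the assay rather than a number: in this assay compound 3 gives > 1000 nM. This is the single entry sitting at the limit (the limit of > 1000 nM in this assay, at which 1 of the 3 values shown sits).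

Compound 4 `CC(C)Cn1nc(-c2cccs2)c(O)c(C2=NS(=O)(=O)c3cc(NS(C)(=O)=O)ccc3N2)c1=O` is not yet measured. It differs from compound 3 by isopropyl in place of neopentyl on a saturated chain carbon bound to an aromatic nitrogen. For the measured compounds named here, no pair of measured compounds supplies a step in this assay, so nothing measured shows how this change moves the read-out; the expectation is for no step beyond the scatter in either direction. Compound 4 is expected to give 1500 nM in this assay, with a range from 800 nM to 5000 nM. The estimate for compound 4 means a step that the limit leaves unreadable from compound 3 to compound 4, most likely again reported as a limit rather than a number.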

Compound 4, half-maximal cytotoxic concentration: > 1000 nM
Compound 4: only a limit was reported; the forecaster's own chance of this, stated with the estimate: 80%; the middle value does not contradict the limit.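

Compound 3 and compound 4 both end at a limit in this assay rather than at a number, so no step can be read for isopropyl in place of neopentyl: the limit of > 1000 nM in this assay, at which 2 of the 4 values shown sit.

The compounds shown leave open where the true values of compound 3 and compound 4 lie, and whether this chain change moves the read-out at all.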